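The source may hold more compounds than are shown below. What is called first, only, known or untested is meant among the compounds shown, and "the series" means these compounds.

Working notes on the series. In an ADME assay on microsomes from liver (Rattus norvegicus) for metabolic stability, with a stated time of 10 min (a higher number here means that more of the compound is left, a lower number that less of the compound is left), compound 1 `CC(C)(C)NC(=O)NCCS(=O)(=O)NC(=O)c1ccc(Nc2nc(NC3(c4ccc(Cl)cc4)CC3)nc(OCC(F)(F)F)n2)cc1` gives 93%, compound 2 `CC(C)S(=O)(=O)NC(=O)c1ccc(Nc2nc(NC3(c4ccc(Cl)cc4)CC3)nc(OCC(F)(F)F)n2)cc1` gives 96%, and compound 3 `CCS(=O)(=O)NC(=O)c1ccc(Nc2nc(NC3(c4ccc(Cl)cc4)CC3)nc(OCC(F)(F)F)n2)cc1` gives 85%. Among the three numbers compound 3 stands apart only from compound 2: a number 11 percentage points lower from compound 2 to compound 3 (beyond the scatter), whereas a number 8 percentage points lower from compound 1 to compound 3 (within the scatter) and a number 3 percentage points higher from compound 1 to compound 2 (within the scatter).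

Compound 4 `CNC(=O)NCCS(=O)(=O)NC(=O)c1ccc(Nc2nc(NC3(c4ccc(Cl)cc4)CC3)nc(OCC(F)(F)F)n2)cc1` differs from compound 3 by (methylcarbamoyl)amino in place of hydrogen on a saturated chain carbon, two bonds along the chain from a sulfonyl sulfur. For the measured compounds named here, the one measured step that speaks to this change is the reverse one with a larger group at the same place, a number 8 percentage points lower from compound 1 to compound 3 (within the scatter), which stayed within the scatter. No shift beyond the scatter is therefore expected in this assay. Compound 4 is expected to give 90%, with a range from 78% to 98%. The step expected in this assay is a number 5 percentage points higher from compound 3 to compound 4 (within the scatter).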

Compound 4, percent of the compound remaining in the liver assay: 100%
Beside the measured number, compound 4's estimate is 10 percentage points below it, outside the stated range (above it).
By their numbers in the liver assay, from the lowest: compounds 3, 1, 2 and 4 (each within the scatter of the next, the first and the last beyond it).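

For the compounds shown here, in the liver assay the (methylcarbamoyl)amino group gives the first step beyond the scatter for a change at this place, a number 15 percentage points higher from compound 3 to compound 4 (beyond the scatter), while a number 4 percentage points higher from compound 2 to compound 4 (within the scatter) and a number 7 percentage points higher from compound 1 to compound 4 (within the scatter) show that compound 4 does not separate from compound 2 or compound 1. In a physicochemical assay for permeability, using PAMPA, at pH 7.4 (on this read-out lower numbers stand for lower permeability and higher numbers for higher permeability), compound 3 gives 28 nm/s and compound 4 gives 40 nm/s, and a 1.4-fold higher number from compound 3 to compound 4 (0.15 log units; within the scatter) shows that the same change brings no shift beyond the scatter on this read-out. Nothing available explains either result.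

Open, going by these compounds, is whether an amine or a carboxylic acid in the same place would give a similar step in the liver assay. Also open, on these data alone, is what a longer chain to the sulfonyl sulfur would give in either read-out.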